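Growing the Alkoxy Group on a Fatty Acid Receptor Agonist

A few compounds are considered here, and "the series" means these few. Any claim that something is new, unique, unknown or untested is made for them only; others in the source may bear on it.

Compound 2 `CC#C[C@@H](CC(=O)O)c1ccc(OC[C@H]2COc3ccc(OC)cc3O2)cc1` carries a methoxy group on the outer aromatic ring of its shared core. Within the data shown here, in a functional assay on HEK293 cells for agonist activity at Free fatty acid receptor 1 (Homo sapiens), read by fluorescence and calcium flux, with a stated time of 10 min (on this read-out higher numbers stand for an effect only at larger amounts of compound and lower numbers for an effect already at smaller amounts), compound 2 gives 130 nM, one of only two numbers in hand. The other belongs to compound 1 `CC#C[C@@H](CC(=O)O)c1ccc(OC[C@H]2COc3ccc(F)cc3O2)cc1`, which in this assay gives 210 nM and carries a fluoro group where compound 2 has the methoxy; that exchange reads a 1.6-fold lower number from compound 1 to compound 2 (0.21 log units; within the scatter). Compound 3 `CC#C[C@@H](CC(=O)O)c1ccc(OC[C@H]2COc3ccc(OC(C)C)cc3O2)cc1` differs from compound 2 only by isopropyl in place of methyl on an oxygen on an aromatic ring. Among the measured compounds shown here, no measured step enlarges an alkyl group on this oxygen, and the one step known replaces a fluoro by a methoxy and stays within the scatter, so it offers little guidance for the step at hand. The step from compound 2 to compound 3 is therefore expected to be no change at the digits printed from compound 2 to compound 3 (within the scatter), nothing beyond the scatter. Compound 3 is estimated to give 130 nM in this assay, within a range from 45 nM to 400 nM.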

Compound 3, half-maximal effective concentration: 280 nM
The estimate for compound 3 lay 2.2-fold (0.33 log units) below the measured number; low and high end bracket the measured number.
By their numbers in this assay, from the lowest: compounds 2, 1 and 3 (each within the scatter of the next, the first and the last beyond it).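

Enlarging the alkyl group on this oxygen gives the first step in this set that lies beyond the usual scatter: in this assay, isopropyl in place of methyl gives a 2.2-fold higher number from compound 2 to compound 3 (0.33 log units; beyond the scatter), a modest change. Replacing fluoro with isopropoxy on an aromatic carbon gives a 1.3-fold higher number from compound 1 to compound 3 (0.12 log units; within the scatter), so this assay does not separate these two compounds, even though methoxy and isopropoxy are separated. Nothing available explains the step from methoxy to isopropoxy.

Going by these compounds, the size effect at this oxygen rests on a single pair of compounds, so it remains open whether an ethoxy group would fall in line with methoxy or with isopropoxy. A longer chain such as butoxy, or an amine at the same place, also remains to be read.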